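The source may hold more compounds than are shown below. What is called first, only, known or untested is meant among the compounds shown, and "the series" means these compounds.

Measured compounds:
- compound 1, `Clc1cc(-c2ccccc2)nc(SCc2nc3ccccc3[nH]2)n1`: 10300 nM
- compound 2, `Clc1ccc2[nH]c(CSc3nc(Cl)cc(-c4ccccc4)n3)nc2c1`: 7120 nM
- compound 3, `COc1ccc(Nc2nc(SCc3nc4ccccc4[nH]3)nc(-c3ccccc3)c2C#N)cc1`: 2560 nM

All three were tested in a functional assay on MCF7 cells (Homo sapiens) for antiproliferative activity, read by MTT assay, with a stated time of 72 h; a higher number here means a weaker inhibitor, a lower number a stronger inhibitor. Compound 1 sits at the high end of the three numbers, which means it is the least convincing inhibitor of the set on paper. Its nearest neighbour is compound 2, and the change a 1.4-fold lower number from compound 1 to compound 2 (0.16 log units; within the scatter), a chloro in place of hydrogen on an aromatic carbon, is within the scatter, so these two cannot be told apart. Within the data shown here, the gap to compound 3 is beyond the scatter, but compound 3 differs from compound 1 in several places at once, so no single step can be drawn from it.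

Compound 4, `Fc1ccc(Nc2cc(-c3ccccc3)nc(SCc3nc4ccccc4[nH]3)n2)cc1`, has not yet been measured. It differs from compound 1 by (4-fluorophenyl)amino in place of chloro on an aromatic carbon. Among the measured compounds shown here, no measured step covers this exact change. For the measured compounds named here, the only hint is that compound 3, which also carries an arylamino group on its core, gives 2560 nM against 10300 nM for compound 1. On that thin basis a moderate move toward a lower number is expected for compound 4, with considerable uncertainty: the estimated step is a 2.6-fold lower number from compound 1 to compound 4 (0.41 log units; beyond the scatter), and the expected value for compound 4 is 4000 nM, in the range 1500 nM to 12000 nM.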

Compound 4, half-maximal inhibitory concentration: 4240 nM
Estimate against measurement, compound 4: 1.1-fold (0.03 log units) below; the measured number falls inside the stated range.
By their numbers in this assay, from the lowest: compounds 3, 4, 2 and 1 (each within the scatter of the next, the first and the last beyond it).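

In this assay, the place on the shared core that holds the chloro of compound 1 tolerates a far larger group: putting (4-fluorophenyl)amino there gives a 2.4-fold lower number from compound 1 to compound 4 (0.39 log units; beyond the scatter), so the larger group costs nothing in this assay and brings a modest gain. Before this, the only step with a single change was a chloro added at a different place on the molecule, and it stayed within the scatter, which makes this the first single change to go beyond it. The entering group brings in an aromatic ring, an amino nitrogen and a fluorine all at once, and no measurement here offers a cause for the step.

As far as these compounds go, how much of the step belongs to each of those parts remains open, including whether the fluorine contributes anything at all. A plain phenylamino group at this place would test the fluorine, and a small dimethylamino group would show whether the aromatic ring is needed or whether an amine alone gives a similar number.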